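The source may report more compounds than this note shows. Statements on the series, on what has been measured and on what is new or still open speak of the compounds shown alone.

Measured so far:
- compound 1, `CNC(=O)c1ccccc1-c1ccc(CNc2ncccc2NC(=O)CC(F)(F)F)cc1`: 95%
- compound 2, `COC(=O)c1ccccc1-c1ccc(CNc2nccc(C)c2NC(=O)CC(F)(F)F)cc1`: 40%

For the measured compounds named here, compound 2 stands lowest of the two numbers in an in vivo ADME assay on the whole organism (Rattus norvegicus, strain Sprague Dawley) for pharmacokinetics; on this read-out higher numbers stand for higher oral bioavailability and lower numbers for lower oral bioavailability; the only other compound, compound 1, lies higher by a margin beyond the scatter. Going by the values given here, compound 1 and compound 2 differ in two places at once, so their gap cannot be assigned to either single change; the two values show only that the pair spans a wide range in this assay.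

Compound 3, `CNC(=O)c1ccccc1-c1ccc(CNc2nccc(C)c2NC(=O)CC(F)(F)F)cc1`, has not been measured. It differs from compound 2 in one place: methylamino in place of methoxy on a carbonyl carbon. The ester of compound 2 thus becomes the methylcarbamoyl group that compound 1 carries, while the methyl on the core of compound 2 is kept.

Among the compounds with values here, no measured pair isolates this single change, so its size is not known. Since compound 3 shares the methylcarbamoyl group with compound 1, which gives 95%, an upward step is expected, likely beyond the scatter, but possibly only part of the gap between compound 2 and compound 1.

Compound 3 is estimated at 70%, within 40% to 95%, which means an expected step of a number 30 percentage points higher from compound 2 to compound 3 (beyond the scatter).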

Compound 3, oral bioavailability: 79%
For compound 3 the middle estimate is 9 percentage points below the measured one; measured number inside the range.
By their numbers in this assay, from the lowest: compound 2; then compound 3; then compound 1.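

In this assay, methylamino in place of methoxy on a carbonyl carbon gives a number 39 percentage points higher from compound 2 to compound 3 (beyond the scatter), so 2-(methylcarbamoyl)phenyl in place of 2-(methoxycarbonyl)phenyl is on its own enough to move this read-out by a large margin with the core methyl held constant. With the methylcarbamoyl group held constant, methyl in place of hydrogen on an aromatic carbon gives a number 16 percentage points lower from compound 1 to compound 3 (beyond the scatter), so the wide gap in the earlier pair can now be read as two single changes, the carbonyl change being the larger and the core methyl the more modest. No measurement of any underlying property is available to explain either step.

Going by these compounds, the carbonyl change is read only with the core methyl present and the methyl change only with the methylcarbamoyl group present, so whether either step keeps its size in the other setting remains open. Also open, on these data alone, is how the series responds to other groups on this carbonyl carbon, such as dimethylamino, an unsubstituted amino group, or the hydroxyl of a carboxylic acid.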